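From Fluorophenyl to Bromophenyl: What Compound 4 May Show

The compounds below may be only part of what the source reports. "The series", "measured", "known", "first", "only" and "open" are said of these compounds alone.

Measured so far:
compound 1, `CN(C)C(=S)N/N=C/c1ccc2ccccc2n1`, 50 nM
compound 2, `Fc1ccccc1NC(=S)N/N=C/c1ccc2ccccc2n1`, > 100000 nM
compound 3, `CN(C)C(=S)N/N=C/c1cnc2ccccc2n1`, 90 nM

Three compounds have been run in a functional assay on HL-60 cells (Homo sapiens) for antiproliferative activity, read by sulforhodamine B assay, with a stated time of 72 h; on this read-out higher numbers stand for weaker inhibition and lower numbers for stronger inhibition. Compound 1 `CN(C)C(=S)N/N=C/c1ccc2ccccc2n1` gives 50 nM and compound 3 `CN(C)C(=S)N/N=C/c1cnc2ccccc2n1` gives 90 nM; these two values lie within the usual scatter of each other. Compound 2 `Fc1ccccc1NC(=S)N/N=C/c1ccc2ccccc2n1` stands apart: in this assay it returns only a limit, > 100000 nM, a ceiling of the assay and not a number (the limit of > 100000 nM in this assay, at which 1 of the 3 values shown sits). Of the three, compound 2 is thus the one for which no potency figure exists.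

Compound 4 `S=C(N/N=C/c1ccc2ccccc2n1)Nc1ccc(Br)cc1` has not yet been measured. It is compound 2 with 4-bromophenyl in place of 2-fluorophenyl on an amide-type nitrogen. Among the compounds with values here, no step between two measured compounds describes such an exchange, so the shared core of compound 1 and compound 3 offers no direct guide to what this change does, and the dimethylamino compounds cannot be compared atom for atom with the aryl compounds.

The expectation for compound 4 in this assay is therefore cautious: compound 2 sits at the limit > 100000 nM, and the step of an at least 1.6-fold lower number from compound 2 to compound 4 (0.22 log units; that floor lies within the scatter) is expected to be small or none beyond the scatter. Compound 4 is estimated at 60000 nM, within 5000 nM to 100000 nM, with a fair chance that it too is reported only as a limit.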

Compound 4, half-maximal inhibitory concentration: 27500 nM
For compound 4 the middle estimate is 2.2-fold (0.34 log units) above the measured one; measured number inside the range.
By their numbers in this assay, from the lowest: compounds 1 and 3 (each within the scatter of the next); then compound 4. At a limit, above all of these: compound 2.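

In this assay, 4-bromophenyl in place of 2-fluorophenyl on an amide-type nitrogen brings an at least 3.6-fold lower number from compound 2 to compound 4 (0.56 log units; beyond the scatter). This shows that the choice of aryl group at this position can move the read-out beyond the scatter, and that an aryl compound of this series can return a real number, which compound 2 did not do. The size of the step remains a floor and not a full measure, because compound 2 has no number of its own: the limit of > 100000 nM in this assay, at which 1 of the 4 values shown sits.

The exchange alters both the halogen and where it sits on the ring, and the compounds shown do not separate these two changes, so it remains open which of them matters, or whether both do. Also open, as far as these compounds go, is how other groups on this nitrogen would read in this assay, such as an unsubstituted phenyl, a morpholine or a longer alkyl chain, and whether any of them would carry an aryl-type compound closer to the dimethylamino compounds.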